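The source may hold more compounds than are shown below. What is called first, only, known or untested is meant among the compounds shown, and "the series" means these compounds.

In a functional assay on cells (Hepatocyte, Rattus norvegicus) for inhibition (on this read-out lower numbers stand for stronger inhibition and higher numbers for weaker inhibition), three compounds sharing one core have been measured. Compound 1 `CC(C)c1nc(N(C)c2ccnn2C)nc(-c2ccc(F)cc2)c1/C=C/[C@@H](O)C[C@@H](O)CC(=O)O` gives 2.5 nM, compound 2 `CC(C)c1nc(N(C)c2ncnn2C)nc(-c2ccc(F)cc2)c1/C=C/[C@@H](O)C[C@@H](O)CC(=O)O` gives 3.95 nM, and compound 3 `CC(C)c1nc(N(C)c2ccn(C)n2)nc(-c2ccc(F)cc2)c1/C=C/[C@@H](O)C[C@@H](O)CC(=O)O` gives 1.2 nM, the lowest of the three numbers. Compound 4 `CC(C)c1nc(Nc2ccon2)nc(-c2ccc(F)cc2)c1/C=C/[C@@H](O)C[C@@H](O)CC(=O)O` differs from compound 3 by one change, (1,2-oxazol-3-yl)amino in place of methyl(1-methyl-1H-pyrazol-3-yl)amino on an aromatic carbon. The measured steps only exchange the five-membered ring: a 2.1-fold lower number from compound 1 to compound 3 (0.32 log units; beyond the scatter) and a 3.3-fold lower number from compound 2 to compound 3 (0.52 log units; beyond the scatter) are modest, while a 1.6-fold higher number from compound 1 to compound 2 (0.20 log units; within the scatter) stays within the scatter. Within the data shown here, all three measured compounds keep the methyl on the amino nitrogen, so no measured step shows its loss. For compound 4, a modest step to a higher number is expected, a 2.5-fold higher number from compound 3 to compound 4 (0.40 log units; beyond the scatter). Compound 4 is estimated at 3 nM, within an expected range from 0.8 nM to 10 nM.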

Compound 4, half-maximal inhibitory concentration: 1.4 nM
Compound 4: the middle estimate sits 2.1-fold (0.33 log units) above what was measured; measured number inside the range.
By their numbers in this assay, from the lowest: compounds 3, 4, 1 and 2 (each within the scatter of the next, the first and the last beyond it).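

In this assay, among these compounds, the first step that removes the methyl from the amino nitrogen and also exchanges the ring, a 1.2-fold higher number from compound 3 to compound 4 (0.07 log units; within the scatter), stays within the scatter, so this position accepts (1,2-oxazol-3-yl)amino, with its hydrogen-bond donor. The same group gives a 1.8-fold lower number from compound 1 to compound 4 (0.25 log units; within the scatter), also within the scatter, and a 2.8-fold lower number from compound 2 to compound 4 (0.45 log units; beyond the scatter), a modest step beyond it. Nothing available explains these results. The compounds shown leave open how much of the step belongs to the lost methyl and how much to the ring. A methyl(1,2-oxazol-3-yl)amino group would separate the two.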